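Isobutoxy to butoxy: one step in the series

This account rests on a few compounds, and the source may have more. Where it says the series, first, only, none or still open, it means among the compounds named here.

Two compounds have numbers in a functional assay on BGC-823 cells (Homo sapiens) for cytotoxicity, read by MTT assay, with a stated time of 48 h; on this read-out higher numbers stand for weaker inhibition and lower numbers for stronger inhibition. Compound 1 `CN(C)CCNc1ccnc2cc(OCc3ccc(F)cc3)ccc12` gives 890 nM. Within the data shown here, compound 2 `CC(C)COc1ccc2c(Cl)ccnc2c1` gives 3030 nM, the higher of the two numbers, and its gap to compound 1 lies beyond the scatter; no single-point step links these two, so only the two values themselves can be compared. Compound 3 `CCCCOc1ccc2c(Cl)ccnc2c1` is compound 2 with propyl in place of isopropyl on a saturated chain carbon bound to an oxygen on an aromatic ring. Among the measured compounds shown here, no measured step of this kind exists, so no change beyond the scatter is expected in this assay. The expected step is therefore a 1.1-fold lower number from compound 2 to compound 3 (0.03 log units; within the scatter). Compound 3 is estimated at 2800 nM, within a range from 1100 nM to 7500 nM.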

Compound 3, half-maximal inhibitory concentration: 3610 nM
Compound 3: the middle estimate sits 1.3-fold (0.11 log units) below what was measured; measured number inside the range.
By their numbers in this assay, from the lowest: compound 1; then compounds 2 and 3 (each within the scatter of the next).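

In this assay, among these compounds, a 1.2-fold higher number from compound 2 to compound 3 (0.08 log units; within the scatter) is the first measured step at this place, on a saturated chain carbon bound to an oxygen on an aromatic ring, and it lies within the scatter. Isobutoxy and butoxy therefore cannot be told apart in this assay on the shared core. No other measurement accompanies this step to account for the result.

From the compounds shown here alone, whether a longer chain or an amine in place of butoxy would shift the number beyond the scatter remains open. Also open, going by these compounds, is whether the same change would read alike on the core of compound 1.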